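Swapping 2-chlorophenyl for 3-methoxyphenyl: compound 3 to compound 4

The compounds below may be only part of what the source reports. "The series", "measured", "known", "first", "only" and "open" are said of these compounds alone.

Of the compounds shown here, three sharing one core have been measured in a functional assay on SW 1116 cells (Homo sapiens) for antiproliferative activity, read by MTT assay, with a stated time of 24 h; a lower number here means a stronger inhibitor, a higher number a weaker inhibitor. Compound 1 `O=[N+]([O-])c1cccc(CSc2nnc(-c3ccc4c(c3)OCCO4)n2-c2ccccc2)c1` gives 7590 nM, compound 2 `O=[N+]([O-])c1ccc(CSc2nnc(-c3ccc4c(c3)OCCO4)n2-c2ccccc2)cc1` gives 13800 nM, and compound 3 `Clc1ccccc1CSc1nnc(-c2ccc3c(c2)OCCO3)n1-c1ccccc1` gives 9670 nM. Compound 3 cannot be separated from the other two, as a 1.3-fold higher number from compound 1 to compound 3 (0.11 log units; within the scatter) and a 1.4-fold lower number from compound 2 to compound 3 (0.15 log units; within the scatter) both stay within the scatter.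

The next compound is compound 4 `COc1cccc(CSc2nnc(-c3ccc4c(c3)OCCO4)n2-c2ccccc2)c1`, which carries 3-methoxyphenyl in place of 2-chlorophenyl on a saturated chain carbon bound to a sulfur. The counted difference is 3-methoxyphenyl in place of 2-chlorophenyl on a saturated chain carbon bound to a sulfur.

All three measured steps are exchanges at this same place, so all bear on the new one. Besides the two steps to compound 3, there is a 1.8-fold higher number from compound 1 to compound 2 (0.26 log units; within the scatter), which also stays within the scatter. Going by the values given here, none of the measured compounds carries a methoxy group, so the new group itself remains untested in this assay. With so few compounds, this is thin evidence, and a surprise cannot be ruled out. Even so, no step beyond the scatter is expected, and no direction is favoured. The expected step is a 1.0-fold lower number from compound 3 to compound 4 (0.01 log units; within the scatter). The estimate for compound 4 is 9500 nM, with an expected range of 5000 nM to 18000 nM.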

Compound 4, half-maximal inhibitory concentration: 10100 nM
Estimate against measurement, compound 4: 1.1-fold (0.03 log units) below, and the stated range covers the measured number.
By their numbers in this assay, from the lowest: compounds 1, 3, 4 and 2 (each within the scatter of the next).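

In this assay, a methoxy-bearing ring at this place on a saturated chain carbon bound to a sulfur does not separate from the chloro- and nitro-bearing rings: a 1.0-fold higher number from compound 3 to compound 4 (0.02 log units; within the scatter), a 1.4-fold lower number from compound 2 to compound 4 (0.14 log units; within the scatter) and a 1.3-fold higher number from compound 1 to compound 4 (0.12 log units; within the scatter) all stay within the scatter. The last of these steps is the cleanest new reading, since it exchanges only nitro for methoxy on an aromatic carbon, and the series shows no measurable response to that exchange in this assay. No measurement is available to account for this flat response.

With all four compounds within the scatter of their neighbours, the shown set marks no group at this place as better or worse, and it does not reveal how far the flat response extends. Still open, on these data alone, is whether an amine or a carboxylic acid on the aromatic ring, an unsubstituted phenyl, or a longer chain on the sulfur in place of the benzyl group would give a step beyond the scatter, and whether changes elsewhere on the shared core would do so.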